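A few compounds are considered here, and "the series" means these few. Any claim that something is new, unique, unknown or untested is made for them only; others in the source may bear on it.

In a functional assay on RAW264.7 cells (Mus musculus) for inhibition, read by Griess assay, with stated times of 1 h and 24 h (on this read-out lower numbers stand for stronger inhibition and higher numbers for weaker inhibition), so far:
- compound 1 `C=C/C=C/C/C(I)=C\CC#CC/C=C\C/C(I)=C\CCCC(=O)OC` gives 3900 nM
- compound 2 `C/C=C/CC/C(I)=C\CC#CC/C=C\C/C(I)=C\CCCC(=O)OC` gives 7000 nM

Within the data shown here, compound 2 cannot be separated from compound 1 on these numbers: the only measured step, a 1.8-fold higher number from compound 1 to compound 2 (0.25 log units; within the scatter), stays within the scatter. Compound 3 `C=CCCC/C=C\CC#CC/C=C\C/C(I)=C\CCCC(=O)OC` differs from compound 2 by one change, (hepta-1,6-dien-1-yl in place of 2-iodohepta-1,5-dien-1-yl on a saturated chain carbon bound to a triple-bonded carbon), with hepta-1,6-dien-1-yl in place of 2-iodohepta-1,5-dien-1-yl on a saturated chain carbon bound to a triple-bonded carbon. Among the measured compounds shown here, the measured step concerns a different group, so it is only a weak guide, and no measured pair covers this change. No step beyond the scatter is expected in this assay, and the data give no direction. The step expected is a 1.2-fold lower number from compound 2 to compound 3 (0.07 log units; within the scatter) on this estimate. For compound 3 the estimated value is 6000 nM, with an expected range from 2000 nM to 18000 nM.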

Compound 3, half-maximal inhibitory concentration: 53600 nM
Beside the measured number, compound 3's estimate is 8.9-fold (0.95 log units) below it; the measured number lies above the stated range.
By their numbers in this assay, from the lowest: compounds 1 and 2 (each within the scatter of the next); then compound 3.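

In this assay, among these compounds, this is the first change on a saturated chain carbon bound to a triple-bonded carbon to move the number beyond the scatter: hepta-1,6-dien-1-yl in place of 2-iodohepta-1,5-dien-1-yl gives (a 7.7-fold higher number from compound 2 to compound 3 (0.88 log units; beyond the scatter)), and the wider comparison gives (a 14-fold higher number from compound 1 to compound 3 (1.14 log units; beyond the scatter)). Compound 1 and compound 2, which both keep an iodine in the group at this place, cannot be separated from each other, while compound 3, without that iodine, stands apart from both. No measurement at hand explains this step.

The two heptadienyl groups differ in more than the iodine, so the iodine's share of the step remains unresolved. Also open, on these data alone, is whether a bromine or a methyl group on the same chain would keep the lower numbers.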